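This account rests on a few compounds, and the source may have more. Where it says the series, first, only, none or still open, it means among the compounds named here.

In a functional assay on HL-60 cells (Homo sapiens) for inhibition, read by MTT assay, with a stated time of 72 h (on this read-out lower numbers stand for stronger inhibition and higher numbers for weaker inhibition), compound 2 `Cc1nc(-c2cccc(F)c2)c(C(=O)N2CCN(c3cccc(Cl)c3)CC2)o1` gives 33.7 nM, the lower of the two numbers available. Compound 3 `CCc1nc(-c2cccc(F)c2)c(C(=O)N2CCN(c3cccc(Cl)c3)CC2)o1` gives 317 nM, and compound 1 `O=C(c1oc(C(F)(F)F)nc1-c1cccc(F)c1)N1CCN(c2cccc(Cl)c2)CC1` is reported as "not active" (no number reported). Compound 4 `COc1cc(-c2nc(C)oc2C(=O)N2CCN(c3cccc(Cl)c3)CC2)ccc1O` differs from compound 2 elsewhere: 4-hydroxy-3-methoxyphenyl in place of 3-fluorophenyl on an aromatic carbon, with 4-hydroxy-3-methoxyphenyl in place of 3-fluorophenyl on an aromatic carbon. Within the data shown here, all three measured compounds keep the 3-fluorophenyl, so no measured step covers this change. Among the measured compounds shown here, the one measured step, a 9.4-fold higher number from compound 2 to compound 3 (0.97 log units; beyond the scatter), lies at another place and shows only that a single change can move the number beyond the scatter. A step of similar or smaller size is therefore expected, toward a higher number, since compound 2 already stands low at 33.7 nM. The expected change is a 4.5-fold higher number from compound 2 to compound 4 (0.65 log units; beyond the scatter). For compound 4 the estimated value is 150 nM, with an expected range of 25 nM to 1000 nM.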

Compound 4, half-maximal inhibitory concentration: 85.9 nM
Compound 4: middle estimate off by 1.7-fold (0.24 log units), on the high side; measured number inside the range.
By their numbers in this assay, from the lowest: compound 2; then compound 4; then compound 3.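

Compound 4 is the first change shown at the aromatic carbon of the five-membered ring, and replacing 3-fluorophenyl with 4-hydroxy-3-methoxyphenyl gives a 2.5-fold higher number from compound 2 to compound 4 (0.41 log units; beyond the scatter). This position therefore accepts a larger substituted phenyl with a hydrogen-bond donor and acceptors and still gives a number, though the step lies beyond the scatter. No evidence is available that accounts for this step. The hydroxy and methoxy groups enter together, and the compounds shown do not separate them. Also open, as far as these compounds go, is how a phenyl carrying only a methoxy group, or an amine on that ring, would read here.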